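Lipophilicity along a serine-derived hydroxamate series

A few compounds are considered here, and "the series" means these few. Any claim that something is new, unique, unknown or untested is made for them only; others in the source may bear on it.

Measured compounds:
compound 1, `O=C(N[C@@H](CO)C(=O)NO)c1ccc(C#Cc2ccccc2)cc1`, a physicochemical assay for lipophilicity; a higher number here means a more lipophilic compound, a lower number a more polar compound: 2
compound 2, `CC(NC(=O)c1ccc(C#Cc2ccccc2)cc1)C(=O)NO`, this assay: > 3

Compound 2 stands at a limit of this assay, not at a number: its value of > 3 marks the edge at which (the limit of > 3 in this assay, at which 1 of the 2 values shown sits). Compound 1 gives 2 in this assay. Within the data shown here, the one measured step, a number at least 1.00 log units higher from compound 1 to compound 2 (beyond the scatter), therefore records only a lower bound for the gap between the two.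

Compound 3, `O=C(N[C@H](CO)C(=O)NO)c1ccc(C#Cc2ccccc2)cc1`, is not yet measured. Going from compound 2 to compound 3 it differs by a group of 7 heavy atoms (3 carbon, 1 nitrogen, 3 oxygen; no ring) in place of a group of 6 heavy atoms (3 carbon, 1 nitrogen, 2 oxygen; no ring), on an amide-type nitrogen. Compound 3 shares all its atoms with compound 1 and differs from it only in the defined stereocentre.

The measured step from compound 1 to compound 2 bears directly on this change, since it runs the same exchange in the opposite direction. That step was at least modest in the upward direction; the reverse exchange is therefore expected to lower the distribution coefficient by a comparable amount, as a number at least 1.00 log units lower from compound 2 to compound 3 (beyond the scatter). Because compound 1 gives 2, compound 3 is expected to land near the same value, estimated at 2 with a range of 1.6 to 2.5.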

Compound 3, distribution coefficient: 2
Compound 3: middle estimate and measured number agree at the digits printed; the range from low to high includes it.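

Configuration at the saturated chain carbon does not register in this assay. The reading is no change at the digits printed from compound 1 to compound 3 (within the scatter), and this comparison isolates configuration alone: the fact that compounds 1 and 3 differ only in the configuration as drawn. The exchange on the amide-type nitrogen now gives a number at least 1.00 log units lower from compound 2 to compound 3 (beyond the scatter), so a step beyond the scatter appears with either drawn configuration of the entering group, R here and S in the step already on record. The value of compound 2 is a limit and not a number, so both steps that involve it give only a bound on their size: the limit of > 3 in this assay, at which 1 of the 3 values shown sits.

On these data alone, the true size of the gap to compound 2 stays open, as does the question of which part of the entering group carries the step, since 1-(hydroxycarbamoyl)ethyl and the entering group differ at one site only in this set. Also open, as far as these compounds go, is how an amine, a carboxylic acid or a longer chain in place of that group on the amide-type nitrogen would read in this assay, and whether configuration would still make no difference there.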